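Pentan-3-yl in Place of a Branched Side Chain

The source may report more compounds than this note shows. Statements on the series, on what has been measured and on what is new or still open speak of the compounds shown alone.

Measured compounds:
compound 1 `C[C@@H](/N=c1\c(O)c(O)\c1=N/Cc1ccc(C#N)cc1)C(C)(C)C` 270 nM
compound 2 `CCc1cc(C#N)ccc1C/N=c1\c(O)c(O)\c1=N/[C@H](C)C(C)(C)C` 2000 nM
compound 3 `CCC(C)(C)Nc1c(NCc2c(C)cc(Cl)cc2Cl)c(=O)c1=O` 100 nM

In a functional assay for inhibition, with Rattus norvegicus as the target (a lower number here means a stronger inhibitor, a higher number a weaker inhibitor), compound 1 stands second highest of the three numbers; compound 3 sits nearest, and compound 2, reached by a 7.4-fold higher number from compound 1 to compound 2 (0.87 log units; beyond the scatter), sits furthest. Compound 4 `CCC(CC)/N=c1\c(O)c(O)\c1=N/Cc1ccc(C#N)cc1` is not yet measured. It differs from compound 1 by pentan-3-yl in place of 1,2,2-trimethylpropyl on a double-bonded nitrogen. Among the compounds with values here, no measured step touches this double-bonded nitrogen: the only measured step changes an aromatic carbon, and compound 3 differs from compound 1 in more than one place. Within the data shown here, with no step to lean on, a change of modest size is expected, more likely toward a higher number than a lower one. Compound 4 is therefore estimated at 500 nM, between 150 nM and 2000 nM, a step of a 1.9-fold higher number from compound 1 to compound 4 (0.27 log units; within the scatter).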

Compound 4, half-maximal inhibitory concentration: 1300 nM
The estimate for compound 4 lay 2.6-fold (0.41 log units) below the measured number; low and high end bracket the measured number.
By their numbers in this assay, from the lowest: compound 3; then compound 1; then compounds 4 and 2 (each within the scatter of the next).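

Within the data shown here, compound 4 gives the first measured step at this double-bonded nitrogen: in this assay, pentan-3-yl in place of 1,2,2-trimethylpropyl gives a 4.8-fold higher number from compound 1 to compound 4 (0.68 log units; beyond the scatter) and so lies beyond the scatter. The side chain on this nitrogen therefore affects the number, and this step loses the defined stereocentre that 1,2,2-trimethylpropyl carries, so it cannot separate the stereocentre from the rest of the chain. Nothing available accounts for the step.

From the compounds shown here alone, whether a cyclopentyl or tert-butyl group on this nitrogen would keep the number of compound 1 remains open. So does whether this change would give a similar step alongside the ethyl group of compound 2.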